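A few compounds are considered here, and "the series" means these few. Any claim that something is new, unique, unknown or untested is made for them only; others in the source may bear on it.

Going by the values given here, in a functional assay on Huh-7 cells (Homo sapiens) for antiproliferative activity, read by CCK-8 assay, with a stated time of 72 h (on this read-out higher numbers stand for weaker inhibition of growth and lower numbers for stronger inhibition of growth), compound 1 (`CCC1C(=O)N(C)c2cnc(-n3ccc4cc(C(=O)NC)ccc43)nc2N1c1ccn(C)n1`) gives 13200 nM and compound 2 (`CCNC(=O)c1ccc2c(ccn2-c2ncc3c(n2)N(c2ccn(C)n2)C(CC)C(=O)N3C)c1`) gives 20300 nM, so compound 2 stands within the scatter of the only other measured value. Compound 3 (`CCC1C(=O)N(C)c2cnc(-n3ccc4cc(C(=O)NC5CCCC5)ccc43)nc2N1c1ccn(C)n1`) carries cyclopentyl in place of ethyl on an amide-type nitrogen. Among the compounds with values here, no measured compound carries cyclopentyl there. Within the data shown here, the one measured step that bears on the change is a 1.5-fold higher number from compound 1 to compound 2 (0.19 log units; within the scatter), so no step beyond the scatter is expected in this assay. The expected step is a 1.2-fold lower number from compound 2 to compound 3 (0.08 log units; within the scatter). Compound 3 is estimated at 17000 nM, with an expected range of 6500 nM to 45000 nM.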

Compound 3, concentration for 50% growth inhibition: "not active" (no number reported)
Compound 3 has no reported number here; no gap can be computed for the estimate.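

Going by these compounds alone, compound 3 is reported in this assay as not active, without a number, so no step from compound 2 to compound 3 can be read. How far cyclopentyl in place of ethyl shifts growth inhibition stays open, and no data shown here explain the result.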